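A few compounds are considered here, and "the series" means these few. Any claim that something is new, unique, unknown or untested is made for them only; others in the source may bear on it.

Compound 1 `Clc1ccc(Cn2ccc3nc(-c4ccccc4)nc-3c2)cc1` carries a 4-chlorophenyl group on a saturated chain carbon bound to an aromatic nitrogen of the shared core. In an ADME assay on MDBK cells (Bos taurus) for cytotoxicity (a lower number here means that less compound is tolerated, a higher number that more compound is tolerated), compound 1 gives > 100000 nM, which is a limit of the assay rather than a number. Two measured neighbours alter only a group on an aromatic carbon. Compound 2 `FC(F)(F)c1ccc(Cn2ccc3nc(-c4ccccc4)nc-3c2)cc1` gives 84000 nM, a step of an at least 1.1-fold lower number from compound 1 to compound 2 (0.07 log units; that floor lies within the scatter). Compound 3 `c1ccc(-c2ccc(Cn3ccc4nc(-c5ccccc5)nc-4c3)cc2)cc1` gives 18000 nM, a step of an at least 5.5-fold lower number from compound 1 to compound 3 (0.74 log units; beyond the scatter). Compound 4 `c1ccc(-c2nc3ccn(Cc4ccccn4)cc-3n2)cc1` differs from compound 1 by pyridin-2-yl in place of 4-chlorophenyl on a saturated chain carbon bound to an aromatic nitrogen. Among the compounds with values here, no measured step swaps the whole ring, so these two steps bear on it only loosely; one stays within the scatter and one does not. Compound 4 is therefore expected to show no step beyond the scatter, a number no higher from compound 1 to compound 4 (the limit leaves the size open), with an estimate of 100000 nM ranging from 40000 nM to 250000 nM.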

Compound 4, half-maximal cytotoxic concentration: > 100000 nM
Compound 4 was reported as a limit; the forecaster's own chance of this, stated with the estimate: 60%; the middle value sits exactly at the limit.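

Within the data shown here, compound 1 and compound 4 are both reported only as a limit, so no step between them can be read: the limit of > 100000 nM in this assay, at which 2 of the 4 values shown sit. In this assay the compounds shown leave open whether pyridin-2-yl and 4-chlorophenyl differ at all.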